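Notes on a short series, third compound pending

The compounds below may be only part of what the source reports. "The series", "measured", "known", "first", "only" and "open" are said of these compounds alone.

Measured so far in a functional assay on A549 cells (Homo sapiens) for cytotoxicity, read by MTT assay, with a stated time of 24 h; on this read-out higher numbers stand for weaker inhibition and lower numbers for stronger inhibition:
- compound 1 `Clc1nc(Nc2ccccc2)nc(Nc2ccc(-c3nc4ccccc4o3)cc2)n1` gives 225000 nM
- compound 2 `Fc1ccc(Nc2nc(Cl)nc(Nc3ccc(-c4nc5ccccc5o4)cc3)n2)cc1` gives 254000 nM

Among the measured compounds shown here, compound 2 holds the highest of the two numbers in this assay; its only neighbour is compound 1, and the two lie within the scatter of each other, so no order between them can be read. For the measured compounds named here, the single measured step, a 1.1-fold higher number from compound 1 to compound 2 (0.05 log units; within the scatter), concerns fluoro in place of hydrogen on an aromatic carbon.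

Compound 3 `Clc1nc(NCc2ccccc2)nc(Nc2ccc(-c3nc4ccccc4o3)cc2)n1` is not yet measured. It differs from compound 2 by benzyl in place of 4-fluorophenyl on a nitrogen on an aromatic ring. Going by the values given here, no measured step touches this kind of change: the only step available, a 1.1-fold higher number from compound 1 to compound 2 (0.05 log units; within the scatter), exchanges a hydrogen for a fluorine on an aromatic ring rather than altering the group on the nitrogen. With nothing to lean on, the expected step of a 1.1-fold lower number from compound 2 to compound 3 (0.02 log units; within the scatter) is none beyond the scatter, and the estimate carries a wide range. Compound 3 is therefore expected at 240000 nM, between 90000 nM and 600000 nM in this assay.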

Compound 3, half-maximal inhibitory concentration: 296000 nM
For compound 3 the middle estimate is 1.2-fold (0.09 log units) below the measured one; measured number inside the range.
By their numbers in this assay, from the lowest: compounds 1, 2 and 3 (each within the scatter of the next).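

In this assay, benzyl in place of 4-fluorophenyl on a nitrogen on an aromatic ring gives a 1.2-fold higher number from compound 2 to compound 3 (0.07 log units; within the scatter) and benzyl in place of phenyl at the same place gives a 1.3-fold higher number from compound 1 to compound 3 (0.12 log units; within the scatter). Among the compounds shown here, compound 3 thus adds a first change to the group on this nitrogen, and the phenyl, 4-fluorophenyl and benzyl compounds still cannot be put in any order. Nothing on hand beyond these numbers bears on this result.

Open, from the compounds shown here alone, is whether a group of another kind on this nitrogen, such as a longer chain ending in an amine or a carboxylic acid, would give a step beyond the scatter. Also open, going by these compounds, is what replacing the chloro group, carried by all three compounds on the shared core, would do to the number.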